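A hydroxyphenyl amide tested for cell toxicity

The compounds below may be only part of what the source reports. "The series", "measured", "known", "first", "only" and "open" are said of these compounds alone.

Three amides sharing one core have been measured in a toxicity assay on THP-1 cells (Homo sapiens) for inhibition; on this read-out higher numbers stand for lower toxicity in this test and lower numbers for higher toxicity in this test. Compound 1 `Cn1c(-c2cccc(C#N)c2)cnc1NC(=O)c1ncc[nH]1` gives > 50000 nM, which is a limit of the test rather than a number. Compound 3 `COc1ccc(-c2cnc(NC(=O)c3cccc([N+](=O)[O-])c3)n2C)cc1` gives > 100000 nM, again a limit. Compound 2 `COc1ccc(-c2cnc(NC(=O)CCc3ccccc3)n2C)cc1` gives > 100000 nM, also a limit. Within the data shown here, every value shown is thus a limit; the limit of > 100000 nM in this assay, at which 2 of the 3 values shown sit, holds two of them and the limit of > 50000 nM in this assay, at which 1 of the 3 values shown sits, the third, so no compound has yet produced a measurable number, and nothing separates compound 2 from the others beyond the scatter.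

Compound 4 `COc1ccc(-c2cnc(NC(=O)c3ccc(O)cc3)n2C)cc1` differs from compound 2 in one place: 4-hydroxyphenyl in place of phenethyl on a carbonyl carbon. Among the measured compounds shown here, no step between measured compounds is available to gauge such a change, but the nitro-bearing compound 3 and the nitrile-bearing compound 1 show that quite different amide ends all remain at a limit in this test.

On that basis, in this assay the expected step is a number no higher from compound 2 to compound 4 (the limit leaves the size open), no movement beyond the scatter. Compound 4 is therefore estimated to sit at about 100000 nM, within a range from 50000 nM to 200000 nM, and most likely to be reported again only as a limit.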

Compound 4, half-maximal cytotoxic concentration: > 100000 nM
Compound 4 gave a limit, no number; the forecaster's own chance of this, stated with the estimate: 85%; the middle value lies on the limit itself.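

In this assay compound 4 and compound 2 both stand at a limit of the test rather than at a number, so no step can be read between them. The compounds shown leave open whether changing the amide end alters toxicity in this assay at all, since all of them remain at limits: the limit of > 100000 nM in this assay, at which 3 of the 4 values shown sit.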